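Carboxyamino in place of sulfonamide on a saturated ring

The source may report more compounds than this note shows. Statements on the series, on what has been measured and on what is new or still open speak of the compounds shown alone.

Compound 1 `CC(=O)N1CCC[C@H](NS(=O)(=O)C(C)C)[C@@H]1CO[C@H]1CC[C@@H](C(C)C)CC1` carries an (isopropylsulfonyl)amino group on the shared core. In a functional assay on CHO-K1 cells for agonist activity at Orexin/Hypocretin receptor type 1 (Homo sapiens), read by FLIPR and calcium flux (on this read-out higher numbers stand for an effect only at larger amounts of compound and lower numbers for an effect already at smaller amounts), compound 1 gives only a limit, > 100000 nM. Compound 2 `CC(=O)N1CCC[C@H](N(C)S(C)(=O)=O)[C@@H]1CO[C@H]1CC[C@@H](C(C)C)CC1` differs in carrying methyl(methylsulfonyl)amino. In this assay compound 2 likewise reaches only a limit, > 100000 nM. The step that the two limits leave unreadable from compound 1 to compound 2 is therefore of unreadable size, since both values sit at the limit of > 100000 nM in this assay, at which 2 of the 2 values shown sit. Compound 3 `CC(=O)N1CCC[C@H](NC(=O)O)[C@@H]1CO[C@H]1CC[C@@H](C(C)C)CC1` brings the change (carboxyamino in place of methyl(methylsulfonyl)amino on a saturated ring carbon). Among the compounds with values here, the one measured step bears only loosely on this change and shows no direction. Compound 3 is thus expected near 100000 nM, between 30000 nM and 300000 nM. The step of a number no higher from compound 2 to compound 3 (the limit leaves the size open) is expected to remain unreadable as well.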

Compound 3, half-maximal effective concentration: > 100000 nM
Compound 3: no number, only a limit; the forecaster's own chance of this, stated with the estimate: 85%; the middle value sits exactly at the limit.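

No step can be read among compound 1, compound 2 and compound 3, since each gives only a limit: (the limit of > 100000 nM in this assay, at which 3 of the 3 values shown sit). In this assay the compounds shown leave open which group on the shared core, if any, would give a readable value.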